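Pyrrolidine nitrogen substituent change in a sulfonamide series

A few compounds are considered here, and "the series" means these few. Any claim that something is new, unique, unknown or untested is made for them only; others in the source may bear on it.

The measured compounds are:
compound 1, `O=C(Cn1ccnc1)N1CCC(NS(=O)(=O)c2cc(S(=O)(=O)c3ccccc3)ccc2C(F)(F)F)CC1`, 30 nM
compound 2, `CC(=O)N1CCC[C@H]1C(=O)N1CCC(NS(=O)(=O)c2cc(S(=O)(=O)c3ccccc3)ccc2C(F)(F)F)CC1`, 160 nM
compound 3, `CN(C)CC(=O)N1CCC[C@H]1C(=O)N1CCC(NS(=O)(=O)c2cc(S(=O)(=O)c3ccccc3)ccc2C(F)(F)F)CC1`, 90 nM

All three were tested in an assay on isolated protein for binding affinity to secreted frizzled-related protein 1 (Homo sapiens), read by fluorescence; a higher number here means a weaker inhibitor, a lower number a stronger inhibitor. Compound 3 stands second highest of the three numbers. Its nearest neighbour is compound 2, and the step of a 1.8-fold lower number from compound 2 to compound 3 (0.25 log units; within the scatter) lies within the usual scatter. Its furthest neighbour is compound 1, and the step of a 3.0-fold higher number from compound 1 to compound 3 (0.48 log units; beyond the scatter) lies beyond the scatter, as does a 5.3-fold higher number from compound 1 to compound 2 (0.73 log units; beyond the scatter).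

Compound 4, `CN1CCC[C@H]1C(=O)N1CCC(NS(=O)(=O)c2cc(S(=O)(=O)c3ccccc3)ccc2C(F)(F)F)CC1`, has not yet been measured. Relative to compound 3 the change is methyl in place of ((dimethylamino)methyl)carbonyl on an amine nitrogen in a ring. Among the compounds with values here, no measured step removes an acyl group from this nitrogen; the only step that touches this region is a 1.8-fold lower number from compound 2 to compound 3 (0.25 log units; within the scatter), which stayed within the scatter. The step from compound 1 to compound 3, a 3.0-fold higher number from compound 1 to compound 3 (0.48 log units; beyond the scatter), shows that changes at the carbonyl-bearing side chain can move the number modestly.

For compound 4 the expected step is a 1.1-fold higher number from compound 3 to compound 4 (0.05 log units; within the scatter), with no firm direction. The estimate for compound 4 in this assay is 100 nM, ranging from 30 nM to 320 nM.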

Compound 4, half-maximal inhibitory concentration: 120 nM
For compound 4 the middle estimate is 1.2-fold (0.08 log units) below the measured one; the measured number falls inside the stated range.
By their numbers in this assay, from the lowest: compound 1; then compounds 3, 4 and 2 (each within the scatter of the next).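

In this assay, the amine nitrogen of the five-membered ring now carries a plain methyl rather than an acyl group, and this shows that the reading at this position stays within the scatter across a large change in substituent: replacing ((dimethylamino)methyl)carbonyl gives a 1.3-fold higher number from compound 3 to compound 4 (0.12 log units; within the scatter) and replacing acetyl gives a 1.3-fold lower number from compound 2 to compound 4 (0.12 log units; within the scatter). Compound 4 nevertheless stays apart from compound 1 (a 4.0-fold higher number from compound 1 to compound 4 (0.60 log units; beyond the scatter)), so all three compounds with a substituted pyrrolidine now read beyond the scatter from compound 1, whichever of these groups sits on the ring nitrogen. No measurement shown here explains why methyl and the two acyl groups cannot be told apart at this nitrogen.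

The compounds shown leave open whether this insensitivity holds for a bare hydrogen on the ring nitrogen, for a longer alkyl chain, or for a group bearing a carboxylic acid. They also leave open whether a group such as a 1H-imidazol-1-yl attached to this pyrrolidine nitrogen through a short chain would bring the number closer to that of compound 1.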